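Replacing thiophen-2-yl with phenethyl on the shared core

The source may hold more compounds than are shown below. What is called first, only, known or untested is meant among the compounds shown, and "the series" means these compounds.

For the measured compounds named here, in a functional assay on SK-MEL-2 cells (Homo sapiens) for cytotoxicity, read by sulforhodamine B assay, with a stated time of 2 days, tested at 100 uM (a lower number here means less inhibition, a higher number more inhibition at the concentration tested (going by the name of the read-out)), compound 1 `O=C(Nn1c(-c2cccc([N+](=O)[O-])c2)nc2c(-c3ccc(Cl)cc3)n[nH]c2c1=O)c1cccnc1` gives 16.3%, and compound 2 `O=C(Nn1c(-c2cccc([N+](=O)[O-])c2)nc2c(-c3cccs3)n[nH]c2c1=O)c1cccnc1` gives 3.26%, the lowest of the two numbers; the only measured step is a number 13 percentage points lower from compound 1 to compound 2 (beyond the scatter). Compound 3 `O=C(Nn1c(-c2cccc([N+](=O)[O-])c2)nc2c(CCc3ccccc3)n[nH]c2c1=O)c1cccnc1` differs from compound 2 by phenethyl in place of thiophen-2-yl on an aromatic carbon. Going by the values given here, no measured step exchanges a five-membered aromatic ring for a phenethyl chain, so the one step gives only a loose guide. Because compound 2 gives 3.26% and the aromatic ring in compound 1 reached only 16.3%, compound 3 is expected to stay low, with a step of a number 4.7 percentage points higher from compound 2 to compound 3 (within the scatter), within the scatter. The estimate for compound 3 is 8%, ranging from 0% to 25%.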

Compound 3, a percentage reported as inhibition, at one concentration (the size of the read-out at that concentration, not a potency): 28.5%
Beside the measured number, compound 3's estimate is 20.5 percentage points below it; measured number above the stated range.
By their numbers in this assay, from the lowest: compound 2; then compound 1; then compound 3.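

Phenethyl on this aromatic carbon gives a number 25.2 percentage points higher from compound 2 to compound 3 (beyond the scatter), and it also gives a number 12.2 percentage points higher from compound 1 to compound 3 (beyond the scatter). The earlier compounds shown here carried only aromatic rings set on this carbon itself, and they did not show that a group holding its ring out on a chain could give the highest of the three numbers. No measurement here bears on the reason for this rise. Going by these compounds, whether the rise belongs to the chain or to the ring at its end stays open, as does what benzyl, phenylpropyl or an amine at this carbon would give.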